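The source may hold more compounds than are shown below. What is called first, only, known or untested is meant among the compounds shown, and "the series" means these compounds.

Three compounds in this series have been measured in a functional assay on the whole organism (strain CF-1 albino) with Mus musculus as the target, with a stated time of 4 h; a higher number here means that more compound is needed for the effect, a lower number that less compound is needed:

Compound 1 `O=C1CC(c2ccccc2Br)C(=O)N1CN1CCN(c2ccccc2)CC1` — 100 mg/kg
Compound 2 `O=C1CC(c2ccccc2Br)C(=O)N1CN1CCN(c2cccc(Cl)c2)CC1` — 100 mg/kg
Compound 3 `O=C1CC(c2ccccc2Br)C(=O)N1CN1CCN(c2cccc(C(F)(F)F)c2)CC1` — 300 mg/kg

Compound 3 stands at the highest of the three numbers. Its nearest neighbour is compound 1, and the step of a 3.0-fold higher number from compound 1 to compound 3 (0.48 log units; beyond the scatter) lies beyond the scatter; the step of a 3.0-fold higher number from compound 2 to compound 3 (0.48 log units; beyond the scatter) is of the same size. Between the other two, no change at the digits printed from compound 1 to compound 2 (within the scatter), so the chloro group makes no difference that can be seen here.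

Compound 4 `O=C1CC(c2ccccc2Br)C(=O)N1CN1CCN(c2ncccn2)CC1` differs from compound 3 in one place: pyrimidin-2-yl in place of 3-(trifluoromethyl)phenyl on an amine nitrogen in a ring. Among the measured compounds shown here, no measured step exchanges the whole aryl ring on the piperazine nitrogen, so there is no direct precedent for a pyrimidin-2-yl group. For the measured compounds named here, the steps that bear on it are those in which the trifluoromethyl group appears or disappears, a 3.0-fold higher number from compound 1 to compound 3 (0.48 log units; beyond the scatter) and a 3.0-fold higher number from compound 2 to compound 3 (0.48 log units; beyond the scatter), both modest. Compound 4 also loses the trifluoromethyl group, so a modest step back toward the numbers of compounds 1 and 2 is expected, while the new ring itself is a source of uncertainty. The expected step is a 2.0-fold lower number from compound 3 to compound 4 (0.30 log units; within the scatter). Compound 4 is therefore estimated at 150 mg/kg, with a range from 50 mg/kg to 450 mg/kg.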

Compound 4, minimum effective dose: 100 mg/kg
Estimate against measurement, compound 4: 1.5-fold (0.18 log units) above; the range from low to high includes it.
By their numbers in this assay, from the lowest: compounds 1, 2 and 4 (each within the scatter of the next); then compound 3.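

In this assay, the ring on the amine nitrogen can be exchanged outright, not only substituted, without a visible effect: pyrimidin-2-yl gives no change at the digits printed from compound 1 to compound 4 (within the scatter), and against 3-chlorophenyl it gives no change at the digits printed from compound 2 to compound 4 (within the scatter). Among the compounds shown here, a ring with two hetero atoms therefore cannot be told apart here from the two carbon-only rings, which leaves 3-(trifluoromethyl)phenyl as the only one of the four groups set apart, with a 3.0-fold lower number from compound 3 to compound 4 (0.48 log units; beyond the scatter). No measurement is available that would explain why compound 3 stands apart from the other three.

As far as these compounds go, whether any group at this place can bring the number lower than those of compound 1, compound 2 and compound 4 stays open, since these three cannot be separated and none of the four groups improves on the others. From the compounds shown here alone, it is also open how a pyridin-2-yl ring, a benzyl group or a simple alkyl chain on the same amine nitrogen would behave, and whether a methoxy group on the phenyl ring would follow chloro or trifluoromethyl.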